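The compounds below may be only part of what the source reports. "The series", "measured", "known", "first", "only" and "open" are said of these compounds alone.

Measured compounds and their values:
Compound 1 `CC(C)c1onc(-c2c(Cl)cccc2Cl)c1COc1ccc(N(C)Cc2ccc(CCC(=O)O)cc2)c(C(F)(F)F)n1` gives 66% in a functional assay on HEK293 cells for agonist activity at Bile acid receptor (Homo sapiens), read by a luciferase reporter; on this read-out higher numbers stand for larger maximal responses and lower numbers for smaller maximal responses.
Compound 2 `CC(C)c1onc(-c2c(Cl)cccc2Cl)c1COc1ccc(N(C)Cc2cccc(C(=O)O)c2)c(C(F)(F)F)n1` gives 58% in this assay.

Within the data shown here, compound 1 is one of only two measured compounds, and the single measured step, a number 8 percentage points lower from compound 1 to compound 2 (within the scatter), lies within the scatter, so the two cannot be told apart on these numbers. That step exchanges the group on the saturated chain carbon bound to the ring nitrogen, so it shows that changing the acid-bearing group there leaves the maximal response essentially unchanged.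

Compound 3 `CC(C)c1onc(-c2c(Cl)cccc2Cl)c1COc1ccc(N(C)Cc2ccc(C(=O)NS(C)(=O)=O)cc2)c(C(F)(F)F)n1` has not been measured. It differs from compound 1 by (methylsulfonyl)carbamoyl in place of 2-carboxyethyl on an aromatic carbon. Among the measured compounds shown here, the only measured step concerns the same part of the molecule and was within the scatter, so no step beyond the scatter is expected for this change either; no measured step bears directly on the entering group, which leaves the direction open. On that basis the step from compound 1 to compound 3 is expected to be a number 6 percentage points lower from compound 1 to compound 3 (within the scatter). Compound 3 is therefore estimated to give 60% in this assay, with a range from 35% to 85%.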

Compound 3, largest response reached (reported as efficacy), in percent of the reference or control that the assay uses: 67%
Beside the measured number, compound 3's estimate is 7 percentage points below it, within the range that was stated.
By their numbers in this assay, from the lowest: compounds 2, 1 and 3 (each within the scatter of the next).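

Read in this assay, putting (methylsulfonyl)carbamoyl in place of 2-carboxyethyl on the aromatic carbon para to a large group gives a number 1 percentage points higher from compound 1 to compound 3 (within the scatter) and leaves the two compounds indistinguishable. The earlier step changed the group bearing the carboxylic acid but kept a carboxylic acid on both sides, whereas compound 3 has none, so this result shows that a maximal response within the scatter of that of compound 1 does not require a carboxylic acid at this position. Nothing available here explains why the maximal response holds across this exchange.

The compounds shown leave open how a 4-carboxyphenyl group, with the carboxylic acid directly on this aromatic carbon, would compare, and whether a tetrazole, a primary amide, a methyl ester or a longer chain ending in (methylsulfonyl)carbamoyl would also fit this pattern. They also leave open how much of each compound is needed to produce its response, since this read-out records only the largest response reached.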